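Chlorobenzyl sulfanyl variation in the dihydropyrimidine amide series

A few compounds are considered here, and "the series" means these few. Any claim that something is new, unique, unknown or untested is made for them only; others in the source may bear on it.

Two compounds have numbers in a functional assay on the whole organism (artery, strain albino) with Rattus norvegicus as the target, with a stated time of 900 min, at a dose of 10 mg/kg by the oral route; on this read-out lower numbers stand for less inhibition and higher numbers for more inhibition at the one dose given (going by the name of the read-out). Compound 1 `COc1ccc(C2N=C(SCc3ccccc3Cl)NC(C)=C2C(=O)Nc2ccc(Br)cc2)cc1` gives 7.2% in this assay. Within the data shown here, compound 2 `COc1ccc(C2N=C(SCc3cccc(Cl)c3)NC(C)=C2C(=O)Nc2ccc(Br)cc2)cc1` gives 22.6% in this assay, the higher of the two values, with the only other measured number sitting a number 15.4 percentage points higher from compound 1 to compound 2 (beyond the scatter). Compound 3 `COc1ccc(C2N=C(SCc3ccc(Cl)cc3)NC(C)=C2C(=O)Nc2ccc(Br)cc2)cc1` is not yet measured; it differs from compound 2 by 4-chlorophenyl in place of 3-chlorophenyl on a saturated chain carbon bound to a sulfur. Among the measured compounds shown here, the one measured step that bears on this change is the move of the chlorine from 2-chlorophenyl to 3-chlorophenyl on the same saturated chain carbon bound to a sulfur, which went a number 15.4 percentage points higher from compound 1 to compound 2 (beyond the scatter). That single step gives no basis for saying whether a further move of the chlorine along the ring continues in the same direction, reverses, or stays flat. A step near the scatter edge in either direction is the expected outcome, so the estimated step is a number 2.4 percentage points higher from compound 2 to compound 3 (within the scatter). Compound 3 is therefore expected to give about 25% in this assay, within a range of 5% to 45%.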

Compound 3, a percentage reported as inhibition, in the whole organism at one dose (the size of the read-out at that dose, not a potency): 20%
Estimate against measurement, compound 3: 5 percentage points above; the range from low to high includes it.
By their numbers in this assay, from the lowest: compound 1; then compounds 3 and 2 (each within the scatter of the next).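

In this assay, moving the chlorine once more gives a number 2.6 percentage points lower from compound 2 to compound 3 (within the scatter), so 3-chlorophenyl and 4-chlorophenyl on a saturated chain carbon bound to a sulfur cannot be told apart at this dose. The 2-chlorophenyl compound now stands apart from both, with a number 15.4 percentage points higher from compound 1 to compound 2 (beyond the scatter) joined by a number 12.8 percentage points higher from compound 1 to compound 3 (beyond the scatter), which shows that the low number of compound 1 is not a feature of a single pair but holds against each of the other two chlorine placements. No measurement on hand bears on what lies behind these differences.

The compounds shown leave open whether the chlorine is needed at all, which a plain benzyl or a fluorine or methoxy in its stead would test. Also open, from the compounds shown here alone, is whether a phenethyl, a longer chain in place of the benzyl, would hold the numbers of compound 2 and compound 3.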